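Swapping 3-methoxyphenyl for 4-acetylphenyl on compound 2

The source may report more compounds than this note shows. Statements on the series, on what has been measured and on what is new or still open speak of the compounds shown alone.

In an ADME assay on WI-38 cells (Homo sapiens) for cytotoxicity, read by MTT assay, with a stated time of 72 h (a lower number here means a stronger inhibitor, a higher number a weaker inhibitor), compound 1 `O=C(CCc1cccc2c1B(O)OC2)Nc1ccc(I)cc1` gives 49000 nM as a measured number. Compound 2 `COc1cccc(-c2cccc(NC(=O)CCc3ccc4c(c3)COB4O)c2)c1` reads > 100000 nM and that is a limit of the assay, not a number. Going by the values given here, the data so far thus show the limit of > 100000 nM in this assay, at which 1 of the 2 values shown sits, and no measured step joins these two compounds.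

Compound 3 `CC(=O)c1ccc(-c2cccc(NC(=O)CCc3ccc4c(c3)COB4O)c2)cc1` differs from compound 2 by carrying 4-acetylphenyl in place of 3-methoxyphenyl on an aromatic carbon, meta to a large group (4-acetylphenyl in place of 3-methoxyphenyl on an aromatic carbon). Among the compounds with values here, no measured step speaks to this change, so no shift beyond the scatter is expected in this assay and no direction is favoured. Within the data shown here, the only measured number, from compound 1 at 49000 nM in this series, suggests that a weak reading is expected here too. The expected change is a number no higher from compound 2 to compound 3 (the limit leaves the size open) as an estimate. For compound 3 the estimate is 100000 nM with an expected range from 40000 nM to 250000 nM in this assay.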

Compound 3, half-maximal inhibitory concentration: > 100000 nM
Compound 3 gave a limit, no number; the forecaster's own chance of this, stated with the estimate: 60%; the middle value sits exactly at the limit.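

Going by these compounds alone, compound 3 and compound 2 are both limits of the assay, not numbers, so no step between them can be read because neither gives a measured value: the limit of > 100000 nM in this assay, at which 2 of the 3 values shown sit. The compounds shown leave open whether 4-acetylphenyl in place of 3-methoxyphenyl changes anything in this assay.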